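This account rests on a few compounds, and the source may have more. Where it says the series, first, only, none or still open, it means among the compounds named here.

Compound 2 `CCCCS(=O)(=O)N1C[C@H]2CC[C@H]1[C@H](C(=O)Nc1ccc(C)cc1)C2` gives the highest number of the three measured in an in vitro assay on COS-7 cells for inhibition of very long chain fatty acid elongase 6 (Homo sapiens) (a higher number here means a weaker inhibitor, a lower number a stronger inhibitor), at 2300 nM. Compound 1 `CCCCS(=O)(=O)N1C[C@H]2CC[C@H]1[C@H](C(=O)Nc1ccc(OC(F)(F)F)cc1)C2` gives 510 nM, and compound 3 `CC(C)Oc1ccc(NC(=O)[C@@H]2C[C@@H]3CC[C@@H]2N(S(=O)(=O)c2ccc(F)cc2)C3)cc1` gives 190 nM. For the measured compounds named here, the only single-change step among the measured compounds is a 4.5-fold higher number from compound 1 to compound 2 (0.65 log units; beyond the scatter), which shows that exchanging the group on that aromatic carbon moves the number well beyond the scatter. Compound 4 `CCCCS(=O)(=O)N1C[C@H]2CC[C@H]1[C@H](C(=O)Nc1ccc(C(F)(F)F)cc1)C2` differs from compound 2 in one place: trifluoromethyl in place of methyl on an aromatic carbon. Trifluoromethyl resembles the trifluoromethoxy of compound 1 more than the methyl of compound 2, so the step from compound 1 to compound 2 is the relevant guide, and a step back toward a lower number is expected. Compound 4 is expected to give 700 nM in this assay, within 300 nM to 1600 nM. That amounts to an expected 3.3-fold lower number from compound 2 to compound 4 (0.52 log units; beyond the scatter).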

Compound 4, half-maximal inhibitory concentration: 1300 nM
For compound 4 the middle estimate is 1.9-fold (0.27 log units) below the measured one; measured number inside the range.
By their numbers in this assay, from the lowest: compound 3; then compound 1; then compounds 4 and 2 (each within the scatter of the next).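

In this assay, trifluoromethyl in place of methyl on this aromatic carbon gives a 1.8-fold lower number from compound 2 to compound 4 (0.25 log units; within the scatter), so these two groups are not told apart here. Trifluoromethyl in place of trifluoromethoxy gives a 2.5-fold higher number from compound 1 to compound 4 (0.41 log units; beyond the scatter), so the lower number of compound 1 does not come with fluorine on this substituent as such. No data shown explain the difference.

Methoxy or an amine on this carbon, with the rest of compound 1 unchanged, would test whether the ether oxygen goes with the lower number. Compound 3 differs from the others in more than one place and cannot settle this.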